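The source may report more compounds than this note shows. Statements on the series, on what has been measured and on what is new or still open speak of the compounds shown alone.

Measured so far in an ADME assay for permeability, using PAMPA, with a stated time of 3 h; a higher number here means that the compound crosses the layer faster, a lower number that the compound crosses the layer more slowly:
- compound 1 `O=C(Nc1ccc([N+](=O)[O-])cc1)c1cc(Cl)ccc1O` gives 12.4 10^-6 cm/s
- compound 2 `O=C(Nc1cccc(Cl)c1)c1cc(Cl)ccc1O` gives 8.6 10^-6 cm/s
- compound 3 `O=C(Nc1ccc(F)c(Cl)c1)c1cc(Cl)ccc1O` gives 11.5 10^-6 cm/s

Compound 2 lies within the usual scatter of the other two compounds, so the three cannot be ranked. Compound 4 `O=C(Nc1cccc(O)c1)c1cc(Cl)ccc1O` departs from compound 2 by one change: hydroxy in place of chloro on an aromatic carbon. This is hydroxy in place of chloro on an aromatic carbon. Among the compounds with values here, the only measured step, a 1.3-fold higher number from compound 2 to compound 3 (0.13 log units; within the scatter), is a different change, fluoro in place of hydrogen, so it gives no direct size for this one. Within the data shown here, no measured compound carries the hydroxy, which leaves the expectation a judgement from the structural change alone. A moderate fall is expected in this assay, an estimated 1.9-fold lower number from compound 2 to compound 4 (0.28 log units; within the scatter). For compound 4 the estimated value is 4.5 10^-6 cm/s, with an expected range from 1.5 10^-6 cm/s to 10 10^-6 cm/s.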

Compound 4, apparent permeability: 15.9 10^-6 cm/s
Estimate against measurement, compound 4: 3.5-fold (0.55 log units) below; measured number outside the range, above it.
By their numbers in this assay, from the lowest: compounds 2, 3, 1 and 4 (each within the scatter of the next).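

In this assay, hydroxy in place of chloro on this aromatic carbon, meta to a large group, gives a 1.8-fold higher number from compound 2 to compound 4 (0.27 log units; within the scatter). At this position, then, exchanging chloro for a group that carries a hydrogen-bond donor and acceptor does not separate compound 4 from compound 2 beyond the scatter. No measurement at hand explains this result. From the compounds shown here alone, whether an amine, a methoxy or a carboxylic acid at this position would also stay within the scatter remains open. So does whether the hydroxy would give the same result alongside the fluoro of compound 3.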